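The source may report more compounds than this note shows. Statements on the series, on what has been measured and on what is new or still open speak of the compounds shown alone.

Compound 3 `Cn1ccnc1SCC(=O)Nc1ccc(-c2nc(-c3ccccc3)c(-c3ccccc3)n2C)cc1` stands second highest of the three numbers in a functional assay on MCF7 cells (Homo sapiens) for cytotoxicity, read by MTT assay, with a stated time of 24 h, tested at 1.6 ug/mL (a higher number here means a stronger effect of the compound at the concentration tested, a lower number a weaker effect), giving 17.5%. The nearest is compound 2 `Cn1c(-c2ccc(NC(=O)CSc3nc4ccccc4o3)cc2)nc(-c2ccccc2)c1-c1ccccc1` with 27.4%, a gap within the scatter, and the furthest is compound 1 `Cn1c(-c2ccc(NC(=O)CCl)cc2)nc(-c2ccccc2)c1-c1ccccc1` with 4.3%. Compound 4 `CN(C)/C=C/N1CCN(CC(=O)Nc2ccc(-c3nc(-c4ccccc4)c(-c4ccccc4)n3C)cc2)CC1` differs by 4-(2-(dimethylamino)ethenyl)piperazin-1-yl in place of (1-methyl-1H-imidazol-2-yl)sulfanyl on a saturated chain carbon bound to a carbonyl carbon. Going by the values given here, the measured steps at that carbon are a number 23.1 percentage points higher from compound 1 to compound 2 (beyond the scatter) and a number 13.2 percentage points higher from compound 1 to compound 3 (beyond the scatter), both replacing chloro by a sulfanyl group; the only exchange of one group for another there, a number 9.9 percentage points lower from compound 2 to compound 3 (within the scatter), lay within the scatter. Among the compounds with values here, no step covers a non-aromatic ring at that position. A change of modest size at most is therefore expected in this assay, with the direction open. Compound 4 is estimated at 18% with a range of 5% to 32%. The expected step is a number 0.5 percentage points higher from compound 3 to compound 4 (within the scatter).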

Compound 4, a percentage reported as activity, at one concentration (the size of the read-out at that concentration, not a potency): 1.9%
Compound 4: middle estimate off by 16.1 percentage points, on the high side, and the stated range ends above it.
By their numbers in this assay, from the lowest: compounds 4 and 1 (each within the scatter of the next); then compounds 3 and 2 (each within the scatter of the next).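

At the saturated chain carbon bound to a carbonyl carbon, in this assay, 4-(2-(dimethylamino)ethenyl)piperazin-1-yl reads lower than either sulfanyl group, with a number 15.6 percentage points lower from compound 3 to compound 4 (beyond the scatter) and a number 25.5 percentage points lower from compound 2 to compound 4 (beyond the scatter). Both sulfanyl groups read higher than chloro, but this larger non-aromatic group does not, with a number 2.4 percentage points lower from compound 1 to compound 4 (within the scatter), so size alone does not carry the gain among these compounds. No measurement at hand explains this drop. As far as these compounds go, it remains open whether the piperazine ring or its 2-(dimethylamino)ethenyl group sets the low reading, and how a morpholine ring or a plain dimethylamino group would read at this carbon.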